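Dropping the Cyano Group from Compound 3

The source may hold more compounds than are shown below. What is called first, only, known or untested is meant among the compounds shown, and "the series" means these compounds.

Measured in a functional assay (aorta) with Rattus norvegicus as the target; on this read-out lower numbers stand for an effect already at smaller amounts and higher numbers for an effect only at larger amounts of compound:
- compound 1 `C/N=C(/NC)Nc1nc(-c2ccc(OC)cc2)c(-c2ccc(OC)cc2)s1`: 2.4 uM
- compound 2 `COc1ccc(-c2nc(C(=O)N3CCCCC3)sc2-c2ccc(OC)cc2)cc1`: 11 uM
- compound 3 `CCOC(=O)/C(C#N)=C/c1nc(-c2ccc(OC)cc2)c(-c2ccc(OC)cc2)s1`: > 100 uM (a limit)

Compound 3 stands at the limit of > 100 uM in this assay, at which 1 of the 3 values shown sits. That is a limit and not a number, so how far compound 3 lies from the other two compounds is known only in one direction.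

The next compound, compound 4 `CCOC(=O)/C=C/c1nc(-c2ccc(OC)cc2)c(-c2ccc(OC)cc2)s1`, has not yet been measured. It replaces 2-cyano-2-(ethoxycarbonyl)ethenyl with 2-(ethoxycarbonyl)ethenyl on the same aromatic carbon: 2-(ethoxycarbonyl)ethenyl in place of 2-cyano-2-(ethoxycarbonyl)ethenyl on an aromatic carbon. The two 4-methoxyphenyl groups stay in place.

Among the measured compounds shown here, no measured step makes this change alone, so the evidence is indirect. The group on this carbon has already mattered in this assay. The data show an at least 41-fold higher number from compound 1 to compound 3 (1.61 log units; beyond the scatter), which is large. They also show an at least 9.0-fold higher number from compound 2 to compound 3 (0.95 log units; beyond the scatter), and a 4.6-fold higher number from compound 1 to compound 2 (0.66 log units; beyond the scatter), which is modest. Since compound 4 keeps most of the group of compound 3, it is expected to remain on the weak side, yet it may well come back towards compound 2 at 11 uM. A modest step to a lower number is therefore expected, and a result reported only as a limit remains possible.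

For compound 4, the estimate means an at least 2.5-fold lower number from compound 3 to compound 4 (0.39 log units; beyond the scatter).

For compound 4, the expected value in this assay is 40 uM, with an estimated range from 10 uM to 150 uM.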

Compound 4, concentration for half-maximal effect: > 100 uM
Compound 4 ended at the assay's limit (the forecaster's own chance of this, stated with the estimate: 35%); middle value at least 2.5-fold (0.39 log units) from the limit.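

In this assay compound 4 gives > 100 uM, which is a limit of the assay. The nitrile alone therefore does not account for the gap to the two better compounds, since with 2-(ethoxycarbonyl)ethenyl on the same aromatic carbon the data still show an at least 9.0-fold higher number from compound 2 to compound 4 (0.95 log units; beyond the scatter) and an at least 41-fold higher number from compound 1 to compound 4 (1.61 log units; beyond the scatter). The step from compound 3 to compound 4 cannot be read, so what the nitrile itself contributes on this read-out stays unknown: the limit of > 100 uM in this assay, at which 2 of the 4 values shown sit.

The compounds shown do not tell whether the weak result goes with the ethenyl link or with the ethyl ester, a question that a carboxylic acid in place of the ester, or a saturated chain in place of the ethenyl link, would help to separate. They also leave open how far past the limit compound 3 and compound 4 really lie, and whether a simple amine on this aromatic carbon would come closer to compound 1, whose group is the best of those shown here.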